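A few compounds are considered here, and "the series" means these few. Any claim that something is new, unique, unknown or untested is made for them only; others in the source may bear on it.

Working notes on the series. Three compounds have been run in a functional assay on K562 cells (Homo sapiens) for inhibition, read by fluorescence, with a stated time of 72 h; on this read-out lower numbers stand for stronger inhibition of growth and higher numbers for weaker inhibition of growth. Compound 1 `CC(C)=CCn1cnc2c(Nc3cccc(Cl)c3)nc(N[C@H]3CC[C@H](N)CC3)nc21` gives 3500 nM in this assay, the highest number of the three, though both others fall within the scatter of it. Compound 2 `CCCCCCn1cnc2c(Nc3ccc(Cl)cc3)nc(N[C@H]3CC[C@H](N)CC3)nc21` gives 2100 nM in this assay, and compound 3 `COc1cc(Nc2nc(N[C@H]3CC[C@H](N)CC3)nc3c2ncn3CCC(C)C)cc(OC)c1` gives 2500 nM in this assay; no ordering among the three can be read from these numbers.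

Compound 4 `N[C@H]1CC[C@H](Nc2nc(Nc3cccc(Cl)c3)c3ncn(Cc4ccccc4)c3n2)CC1` is not yet measured. Relative to compound 1 it carries phenyl in place of 2-methylprop-1-en-1-yl on a saturated chain carbon bound to an aromatic nitrogen. Among the compounds with values here, no measured pair isolates a change of this kind, so the direction is open. The expected step from compound 1 to compound 4, a 1.4-fold lower number from compound 1 to compound 4 (0.15 log units; within the scatter), is estimated to stay within the scatter. In this assay compound 4 is expected to give about 2500 nM, in the range 800 nM to 8000 nM.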

Compound 4, concentration for 50% growth inhibition: 3000 nM
For compound 4 the middle estimate is 1.2-fold (0.08 log units) below the measured one; the measured number falls inside the stated range.
By their numbers in this assay, from the lowest: compounds 2, 3, 4 and 1 (each within the scatter of the next).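

Within the data shown here, this is the first pair that differs in one place. In this assay, phenyl in place of 2-methylprop-1-en-1-yl on a saturated chain carbon bound to an aromatic nitrogen gives a 1.2-fold lower number from compound 1 to compound 4 (0.07 log units; within the scatter), so at this position an aromatic ring and an open alkenyl group cannot be told apart. No measured data bear on why this is so.

Going by these compounds, whether the result holds for a different kind of group at this position, such as an amine or a carboxylic acid, remains open. On these data alone, a substituted phenyl or a longer chain ending in phenyl also remains open.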